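Trading a tetrahydropyranyl pyrazole for an isopropyl pyrazole

The compounds below may be only part of what the source reports. "The series", "measured", "known", "first", "only" and "open" are said of these compounds alone.

Three compounds have been measured in an ADME assay on Caco-2 cells (Homo sapiens) for permeability, in the apical to basolateral direction; a higher number here means that the compound crosses the layer faster, a lower number that the compound crosses the layer more slowly:
- compound 1, `Cn1cc(-c2nc3c(-c4ccc(CN5CCc6cc(C(C)(C)C)ccc6C5=O)c(F)c4)ccnc3[nH]2)cn1`, gives 0.2 10^-6 cm/s
- compound 2, `Cn1cc(-c2nc3c(-c4ccc5c(c4)CCC[C@@H]5NC(=O)c4nc(C(C)(C)C)no4)ccnc3[nH]2)cn1`, gives 5 10^-6 cm/s
- compound 3, `Cc1nn(C2CCOCC2)cc1-c1nc2c(-c3ccc4c(c3)CCC[C@@H]4NC(=O)c3nc(C(C)(C)C)no3)ccnc2[nH]1`, gives 1.3 10^-6 cm/s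

Compound 3 stands second highest of these three numbers in this assay: compound 2 shows a higher number, beyond the scatter, and compound 1 a clearly lower one. Compound 4, `CC(C)n1cc(-c2nc3c(-c4ccc5c(c4)CCC[C@@H]5NC(=O)c4nc(C(C)(C)C)no4)ccnc3[nH]2)cn1`, has not yet been measured. It differs from compound 3 in one place: a group of 8 heavy atoms (6 carbon, 2 nitrogen; one five-membered aromatic ring with 2 hetero atoms) in place of a group of 12 heavy atoms (9 carbon, 2 nitrogen, 1 oxygen; one five-membered aromatic ring with 2 hetero atoms, one six-membered non-aromatic ring with 1 hetero atom), on an aromatic carbon.

Among the measured compounds shown here, the one measured step that bears on this change is a 3.8-fold lower number from compound 2 to compound 3 (0.59 log units; beyond the scatter), in which the very group that now leaves compound 3 had entered in place of a smaller pyrazole. Compound 4 again carries a single pyrazole ring without the six-membered non-aromatic ring, so it resembles compound 2 more than compound 3 in this part, and a step back upward, roughly undoing the earlier drop, is expected: a 3.1-fold higher number from compound 3 to compound 4 (0.49 log units; beyond the scatter). For compound 4 the estimated value in this assay is 4 10^-6 cm/s, with a likely range from 1.5 10^-6 cm/s to 10 10^-6 cm/s.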

Compound 4, apparent permeability: 2.6 10^-6 cm/s
Compound 4: the middle estimate sits 1.5-fold (0.19 log units) above what was measured; low and high end bracket the measured number.
By their numbers in this assay, from the lowest: compound 1; then compounds 3, 4 and 2 (each within the scatter of the next, the first and the last beyond it).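

In this assay, isopropyl can now be compared directly with methyl on this aromatic nitrogen, and the swap stays within the usual scatter (a 1.9-fold lower number from compound 2 to compound 4 (0.28 log units; within the scatter)). Compound 4 also sits within the scatter of compound 3 (a 2.0-fold higher number from compound 3 to compound 4 (0.30 log units; within the scatter)), so neither of its neighbours can be separated from it, even though the earlier step between those two neighbours lay beyond the scatter (a 3.8-fold lower number from compound 2 to compound 3 (0.59 log units; beyond the scatter)). The available data offer no measured explanation for these numbers.

As far as these compounds go, it remains open whether the tetrahydropyranyl ring or the extra methyl on the pyrazole of compound 3 goes with the earlier step, since the two differ from compound 2 together. From the compounds shown here alone, how a cyclopropyl group, a longer chain or a chain bearing an amine on this nitrogen would behave also remains unknown.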